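An Ethyl Group on a Series at Its Limit

The compounds below may be only part of what the source reports. "The series", "measured", "known", "first", "only" and "open" are said of these compounds alone.

Measured in a functional assay on HCT-8 cells (Homo sapiens) for cytotoxicity, read by MTT assay, with a stated time of 24 h; on this read-out lower numbers stand for stronger inhibition and higher numbers for weaker inhibition:
Compound 1 `CC(C)c1cc2c(cc1O)[C@]13CCC[C@]4(C)CO[C@@H]1O[C@H]2C[C@@H]43`: > 10000 nM
Compound 2 `CC(C)c1cc2c(cc1O)[C@]13CCC[C@](C)(CO[C@H]1O)[C@@H]3CC2`: > 10000 nM
Compound 3 `CC(C)c1cc2c(cc1O)[C@]13CCC[C@](C)(CO[C@@H]1O)[C@@H]3CC2`: > 10000 nM

Each of these values is a limit and not a number, and the series offers only (the limit of > 10000 nM in this assay, at which 3 of the 3 values shown sit). Compound 2 therefore has no number that could place it against compound 1 or compound 3. The change to compound 4 `CCO[C@@H]1OC[C@@]2(C)CCC[C@@]13c1cc(O)c(C(C)C)cc1CC[C@@H]23` is ethyl in place of hydrogen on an oxygen on a saturated carbon, which reads as hydroxy to ethoxy. Among the compounds with values here, one measured step bears on compound 2, namely a step that the two limits leave unreadable from compound 2 to compound 3. Within the data shown here, it reflects only (the fact that compounds 2 and 3 differ only in the configuration as drawn), and no measured compound carries a new group on that oxygen. That step therefore gives no size to carry over. No step beyond the scatter is expected in this assay, and no direction can be argued. The expected outcome is a step that the limit leaves unreadable from compound 2 to compound 4, and the assay may well report only a limit again. For compound 4 the estimate is 15000 nM, with an expected range from 6000 nM to 40000 nM.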

Compound 4, half-maximal inhibitory concentration: > 10000 nM
Compound 4 was reported as a limit; the forecaster's own chance of this, stated with the estimate: 75%; the middle value lies beyond the limit too.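

In this assay compound 4 gives > 10000 nM, which is a limit and not a number. No new step can be read from compound 2 to compound 4, and the series stays at one ceiling: the limit of > 10000 nM in this assay, at which 4 of the 4 values shown sit.

The compounds shown leave open whether the change from hydroxy to ethoxy alters cytotoxicity at all.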